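Hydrazone aryl substituent swaps on the shared core

A few compounds are considered here, and "the series" means these few. Any claim that something is new, unique, unknown or untested is made for them only; others in the source may bear on it.

Going by the values given here, compound 2 `O=C(N/N=C/c1ccc([N+](=O)[O-])cc1)Nc1cc2c(Nc3ccc(F)c(Cl)c3)ncnc2cc1O[C@H]1CCOC1` gives 31200 nM in a functional assay on A549 cells (Homo sapiens) for cytotoxicity, read by MTT assay, with a stated time of 72 h (a higher number here means a weaker inhibitor, a lower number a stronger inhibitor), one of two numbers so far; compound 1 `N#Cc1ccc(/C=N/NC(=O)Nc2cc3c(Nc4ccc(F)c(Cl)c4)ncnc3cc2O[C@H]2CCOC2)cc1` gives 29100 nM, and the pair sit within the scatter of each other. Compound 3 `COc1ccc(/C=N/NC(=O)Nc2cc3c(Nc4ccc(F)c(Cl)c4)ncnc3cc2O[C@H]2CCOC2)cc1` differs from compound 2 by methoxy in place of nitro on an aromatic carbon. Among the compounds with values here, the one step measured on this position, nitro in place of cyano on an aromatic carbon, was a 1.1-fold higher number from compound 1 to compound 2 (0.03 log units; within the scatter), so no movement beyond the scatter is expected in this assay for the present change. Compound 3 is therefore estimated at 30000 nM, between 12000 nM and 75000 nM, an expected step of a 1.0-fold lower number from compound 2 to compound 3 (0.02 log units; within the scatter).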

Compound 3, half-maximal inhibitory concentration: 33100 nM
Estimate against measurement, compound 3: 1.1-fold (0.04 log units) below; the measured number falls inside the stated range.
By their numbers in this assay, from the lowest: compounds 1, 2 and 3 (each within the scatter of the next).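

In this assay the change from nitro to methoxy is a 1.1-fold higher number from compound 2 to compound 3 (0.03 log units; within the scatter) and the change from cyano to methoxy is a 1.1-fold higher number from compound 1 to compound 3 (0.06 log units; within the scatter) on the same aromatic carbon. The position now has three substituents that cannot be told apart in this read-out, where before it had only two, and 4-methoxyphenyl reads the same as 4-nitrophenyl. Nothing available explains this lack of separation. From the compounds shown here alone, whether an amine, a carboxylic acid or a longer chain on this carbon would give a number beyond the scatter remains open.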